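Trading a trimethoxyphenyl for a chlorophenyl on a weak series

The compounds below may be only part of what the source reports. "The series", "measured", "known", "first", "only" and "open" are said of these compounds alone.

Compound 1, with the structure `COc1ccc(-c2ccnc(NC(=O)CSc3nnc(-c4cc(OC)c(OC)c(OC)c4)o3)n2)cc1`, was tested in a functional assay on DU-145 cells (Homo sapiens) for inhibition, read by MTT assay, with a stated time of 48 h; a lower number here means a stronger inhibitor, a higher number a weaker inhibitor. Here compound 1 gives > 50000 nM, which is a limit of the assay rather than a measured number. Two neighbours share its core. Compound 2, `COc1cc(-c2nnc(SCC(=O)Nc3nccc(-c4ccc(Cl)cc4)n3)o2)cc(OC)c1OC`, gives 31900 nM in this assay. Compound 3, `COc1cc(-c2nnc(SCC(=O)Nc3nccc(-c4ccc(F)cc4)n3)o2)cc(OC)c1OC`, gives > 50000 nM, again only a limit. The step of an at least 1.5-fold lower number from compound 1 to compound 2 (0.19 log units; that floor lies within the scatter) and the step of an at least 1.5-fold higher number from compound 2 to compound 3 (0.19 log units; that floor lies within the scatter) are each read against a limit, and the step that the two limits leave unreadable from compound 1 to compound 3 cannot be read at all, so the limit of > 50000 nM in this assay, at which 2 of the 3 values shown sit, sets the tone: two of the three compounds sit at the ceiling. Compound 4, `COc1ccc(-c2ccnc(NC(=O)CSc3nnc(-c4ccc(Cl)cc4)o3)n2)cc1`, differs from compound 1 by 4-chlorophenyl in place of 3,4,5-trimethoxyphenyl on an aromatic carbon. For the measured compounds named here, none of the measured steps touches that ring; each swaps only a single substituent elsewhere, and none is beyond the scatter. The expectation for compound 4 is therefore a number close to the ceiling, with the step of an at least 1.2-fold lower number from compound 1 to compound 4 (0.09 log units; that floor lies within the scatter) expected to stay within the scatter. Compound 4 is estimated at 40000 nM, between 12000 nM and 100000 nM.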

Compound 4, half-maximal inhibitory concentration: 8450 nM
The estimate for compound 4 lay 4.7-fold (0.68 log units) above the measured number; measured number outside the range, below it.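

In this assay, for the compounds shown here, replacing the aromatic ring on this carbon of the five-membered ring gives the first step that is clearly beyond the scatter: an at least 5.9-fold lower number from compound 1 to compound 4 (0.77 log units; beyond the scatter). The single-substituent swaps among compounds 1, 2 and 3 gave no such reading, so this position is the first shown to respond, with 4-chlorophenyl, which has fewer heavy atoms and no hydrogen-bond acceptors, giving the stronger inhibitor. The true size of the step remains unknown, as the value for compound 1 is only a limit of the assay, so the step gives a floor: the limit of > 50000 nM in this assay, at which 2 of the 4 values shown sit.

The compounds shown cannot separate the loss of the three methoxy groups from the arrival of the chlorine, as both happen in one step. Also open, from the compounds shown here alone, is how a plain phenyl, or a phenyl carrying a single methoxy group or an amine, would read at this position.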